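A few compounds are considered here, and "the series" means these few. Any claim that something is new, unique, unknown or untested is made for them only; others in the source may bear on it.

Going by the values given here, in a functional assay on LS174T cells (Homo sapiens) for antiproliferative activity (on this read-out higher numbers stand for weaker inhibition and lower numbers for stronger inhibition), compound 1 (`CNc1ccc(/C=C/c2c(F)cccc2F)cc1`) gives 7.6 nM, the lowest of the three numbers so far. Compound 2 (`CCNc1ccc(/C=C/c2c(F)cccc2F)cc1`) gives 200 nM, and compound 3 (`CN(C)c1ccc(/C=C/c2c(F)cccc2Cl)cc1`) gives 19.2 nM. Compound 4 (`CNc1ccc(/C=C/c2c(F)cccc2Cl)cc1`) differs from compound 1 by one change: chloro in place of fluoro on an aromatic carbon. Among the compounds with values here, no measured pair isolates this swap. Within the data shown here, the only measured step, a 26-fold higher number from compound 1 to compound 2 (1.42 log units; beyond the scatter), lies elsewhere in the molecule, so it shows only that a small edit can matter greatly here. Compound 3 carries the chloro but also an extra methyl, and its 19.2 nM suggests a small rise at most. The expected size is a 1.7-fold higher number from compound 1 to compound 4 (0.23 log units; within the scatter), possibly nothing beyond the scatter. Compound 4 is expected at 13 nM, with an estimated range of 5 nM to 35 nM.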

Compound 4, half-maximal inhibitory concentration: 7.6 nM
For compound 4 the middle estimate is 1.7-fold (0.23 log units) above the measured one; low and high end bracket the measured number.
By their numbers in this assay, from the lowest: compounds 1 and 4 (each within the scatter of the next); then compound 3; then compound 2.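

At this aromatic carbon, ortho to a large group, chloro and fluoro cannot be told apart in this assay, with no change at the digits printed from compound 1 to compound 4 (within the scatter). Compound 3 had left the swap mixed with a second methyl on the nitrogen; with chloro held fixed, removing that methyl gives a 2.5-fold lower number from compound 3 to compound 4 (0.40 log units; beyond the scatter), so the methyl change alone separates these two compounds. Nothing available explains why the two halogens read alike. On these data alone, whether a larger group such as bromo or methoxy would fit at this carbon stays open, as does whether hydrogen would do as well.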